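Fluorophenyl for methoxyphenyl on a shared pyridone-type core

The source may hold more compounds than are shown below. What is called first, only, known or untested is meant among the compounds shown, and "the series" means these compounds.

This account follows four compounds built on one core. Compound 1 `C[C@H](Nc1nc(N)nc(N)c1C#N)c1cc2ccc(F)cn2c(=O)c1-c1ccccc1` carries an unsubstituted position where the later analogs bear a substituent; in an assay on 786-0 cells for inhibition of phosphatidylinositol 4,5-bisphosphate 3-kinase catalytic subunit beta isoform (Homo sapiens), with a stated time of 1 h (a lower number here means a stronger inhibitor, a higher number a weaker inhibitor), compound 1 gives 241 nM. Compound 2 `Cc1c([C@H](C)Nc2nc(N)nc(N)c2C#N)c(-c2ccccc2)c(=O)n2cc(F)ccc12` gives "not determined" (no result reported) in this assay, and compound 3 `COc1ccc(-c2c([C@H](C)Nc3nc(N)nc(N)c3C#N)c(-c3ccccc3)c(=O)n3cc(F)ccc23)cc1` gives "not determined" (no result reported) in this assay, so compound 3 stands without a number and cannot be placed against compound 1. Compound 4 `C[C@H](Nc1nc(N)nc(N)c1C#N)c1c(-c2ccccc2)c(=O)n2cc(F)ccc2c1-c1ccc(F)cc1` differs from compound 3 by fluoro in place of methoxy on an aromatic carbon, placed on an aromatic carbon of a six-membered aromatic ring of carbon only, para to a large group. For the measured compounds named here, with no measured step to lean on, a change of this kind is expected to stay within the usual scatter of this assay, in no particular direction. Compound 4 is therefore estimated at 220 nM, with a range from 45 nM to 1100 nM.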

Compound 4, half-maximal inhibitory concentration: 208 nM
Estimate against measurement, compound 4: 1.1-fold (0.02 log units) above; measured number inside the range.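

In this assay, replacing hydrogen with 4-fluorophenyl on the shared core gives a 1.2-fold lower number from compound 1 to compound 4 (0.06 log units; within the scatter), the first readable result at this position: an aromatic ring can stand there without moving the number beyond the scatter. Compound 3 has no number, so the step from methoxy to fluoro cannot be read. Nothing available accounts for this result. Going by these compounds, whether an amine or a carboxylic acid in place of the fluoro would keep the number within the scatter remains open. So does how a methyl group at this position compares, as compound 2 has no number.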